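Swapping Benzyloxy for Benzylsulfanyl in a Receptor Modulator

This account rests on a few compounds, and the source may have more. Where it says the series, first, only, none or still open, it means among the compounds named here.

Compound 1 `O=C(COCc1ccccc1)N1CCN(c2ccc(Cl)cc2)CC1` gives 350 nM in a functional assay on HEK293 cells for positive allosteric modulation of metabotropic glutamate receptor 5 (Homo sapiens), read by FLIPR and calcium flux; a lower number here means that less compound is needed, a higher number that more compound is needed for the effect. Compound 2 `O=C(COCc1ccccc1)N1CCN(c2ccc(Cl)cc2Cl)CC1` gives 1000 nM in this assay, the higher of the two numbers, with the step of a 2.9-fold higher number from compound 1 to compound 2 (0.46 log units; beyond the scatter) being modest but beyond the scatter. Compound 3 `O=C(CSCc1ccccc1)N1CCN(c2ccc(Cl)cc2Cl)CC1` differs from compound 2 at a single spot: benzylsulfanyl in place of benzyloxy on a saturated chain carbon bound to a carbonyl carbon. Among the measured compounds shown here, no measured pair shows a benzylsulfanyl in place of benzyloxy; the only known step concerns a chloro on the aromatic ring and offers no guide here. The expected step is therefore small, no change at the digits printed from compound 2 to compound 3 (within the scatter). Compound 3 is estimated at 1000 nM, within 400 nM to 2500 nM.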

Compound 3, half-maximal effective concentration: 7100 nM
Compound 3: the middle estimate sits 7.1-fold (0.85 log units) below what was measured, and the stated range ends below it.
By their numbers in this assay, from the lowest: compound 1; then compound 2; then compound 3.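

This position is sensitive to the atom in the chain: sulfur in place of oxygen, with everything else unchanged, gives a 7.1-fold higher number from compound 2 to compound 3 (0.85 log units; beyond the scatter) in this assay. The benzyloxy and benzylsulfanyl groups match in heavy atoms, hydrogen-bond donors and hydrogen-bond acceptors, so those counts do not predict the outcome here. No available measurement explains why the exchange has this result.

On these data alone, whether an amine nitrogen or a plain methylene carbon in place of that oxygen would be tolerated remains open. So does whether the same exchange on the core of compound 1 would give a step of similar size.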